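The source may report more compounds than this note shows. Statements on the series, on what has been measured and on what is new or still open speak of the compounds shown alone.

Measured so far:
- Compound 1 `COc1ccc2ncc(S(=O)(=O)c3ccc(C)c(Cl)c3)c(N3CCC(C)CC3)c2c1` gives 85% in an assay on isolated protein for displacement of a labelled ligand from metabotropic glutamate receptor 5 (Homo sapiens), with a stated time of 60 min, tested at 1 uM; on this read-out higher numbers stand for more inhibition at the one concentration tested (going by the name of the read-out) and lower numbers for less inhibition.
- Compound 2 `COc1ccc2ncc(S(=O)(=O)c3ccc(C)c(F)c3)c(N3CCC(C)CC3)c2c1` gives 73% in this assay.
- Compound 3 `CC1CCN(c2c(S(=O)(=O)c3cccc(F)c3)cnc3ccc(Cl)cc23)CC1` gives 58% in this assay.

Compound 3 stands lowest of these three numbers; its nearest neighbour is compound 2, and compound 1 lies furthest above it, both gaps beyond the scatter. The step to compound 4 `COc1ccc2ncc(S(=O)(=O)c3cccc(F)c3)c(N3CCC(C)CC3)c2c1` is the change (methoxy in place of chloro on an aromatic carbon).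

Among the compounds with values here, no measured step covers this exact change. Within the data shown here, the only measured step, a number 12 percentage points lower from compound 1 to compound 2 (beyond the scatter), concerns a different place and a different pair of groups, so it only shows that a single swap of this kind can shift the number modestly. Compounds 1 and 2 both carry methoxy at the place in question and both give higher numbers than compound 3, but each also differs from compound 3 in a second place, so their values cannot be read as a clean step.

On that basis compound 4 is expected to move upward from compound 3 by a number 12 percentage points higher from compound 3 to compound 4 (beyond the scatter), and its estimated value in this assay is 70%, with a likely range from 50% to 88%.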

Compound 4, a percentage reported as inhibition, at one concentration (the size of the read-out at that concentration, not a potency): 68%
Compound 4: the middle estimate sits 2 percentage points above what was measured; the range from low to high includes it.
By their numbers in this assay, from the lowest: compounds 3, 4 and 2 (each within the scatter of the next, the first and the last beyond it); then compound 1.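

In this assay, within the data shown here, the change at this aromatic carbon can now be read cleanly for the first time: methoxy in place of chloro gives a number 10 percentage points higher from compound 3 to compound 4 (within the scatter) and so does not separate the two groups. With methoxy held fixed, hydrogen in place of methyl on an aromatic carbon gives a number 5 percentage points lower from compound 2 to compound 4 (within the scatter) and also makes no clear difference, whereas 3-fluorophenyl in place of 3-chloro-4-methylphenyl on the sulfonyl sulfur gives a number 17 percentage points lower from compound 1 to compound 4 (beyond the scatter) and does register. Of these three new steps, then, only the replacement of the whole group on the sulfonyl sulfur lies beyond the usual scatter.

Still open, on these data alone, is whether an amine or a longer chain such as ethoxy at this aromatic carbon would read differently, or whether chloro and methoxy would stay level alongside 3-chloro-4-methylphenyl. Nothing measured here offers a reason for any of these steps.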